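The compounds below may be only part of what the source reports. "The series", "measured", "known", "first", "only" and "open" are said of these compounds alone.

Measured compounds:
Compound 1, `Cc1cc(OCc2c(-c3cc[nH]c(=O)c3Cl)noc2C(C)C)ccc1-c1ccc2c(C(=O)O)cn(C)c2c1`, gives 7000 nM.
Compound 2, `COc1ccccc1-c1noc(C(C)C)c1COc1ccc(/C=C/c2cccc(C(=O)O)c2)c(Cl)c1`, gives 10000 nM.
Compound 3, `Cc1cc(OCc2c(-c3c(Cl)ccc(=O)n3C)noc2C(C)C)ccc1-c1ccc2c(C(=O)O)cn(C)c2c1`, gives 4000 nM.

All three numbers come from a functional assay for agonist activity at Bile acid receptor (Mus musculus), read by a luciferase reporter; a lower number here means that less compound is needed, a higher number that more compound is needed for the effect. Among them compound 2 gives the highest number. Compound 1 stands within the scatter of compound 2, so the two cannot be told apart on these data. Compound 3 stands beyond the scatter of compound 2, at a lower number.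

The next compound is compound 4, `CC(C)c1onc(-c2c(Cl)cncc2Cl)c1COc1ccc(/C=C/c2cccc(C(=O)O)c2)c(Cl)c1`. It differs from compound 2 in one place: 3,5-dichloropyridin-4-yl in place of 2-methoxyphenyl on an aromatic carbon. The group that changes sits on the five-membered aromatic ring with 1 nitrogen and 1 oxygen, the same kind of position at which compound 1 and compound 3 differ from each other.

Among the compounds with values here, only one measured step touches this position. There, a group with one six-membered aromatic ring with 1 hetero atom was exchanged for a related group, and the result was a 1.8-fold lower number from compound 1 to compound 3 (0.24 log units; within the scatter). That step stayed within the scatter, so it gives no sign that an exchange at this position moves the number far. Compound 1 and compound 2 carry different groups there, on different cores, and their numbers also lie within the scatter of each other.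

On this basis the expected step is a 1.1-fold lower number from compound 2 to compound 4 (0.05 log units; within the scatter), that is, no change beyond the scatter. Compound 4 is therefore estimated at 9000 nM, with a range from 3000 nM to 27000 nM.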

Compound 4, half-maximal effective concentration: 11000 nM
Compound 4: the middle estimate sits 1.2-fold (0.09 log units) below what was measured; the range from low to high includes it.
By their numbers in this assay, from the lowest: compounds 3, 1, 2 and 4 (each within the scatter of the next, the first and the last beyond it).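

The earlier step at this position only exchanged one six-membered aromatic ring with 1 hetero atom for a related one, whereas here a ring of carbon only gives way to 3,5-dichloropyridin-4-yl, and in this assay the step is a 1.1-fold higher number from compound 2 to compound 4 (0.04 log units; within the scatter) and so stays within the scatter. On the core of compound 2, then, a much larger change in the make-up of this group, with a ring nitrogen and two chlorine atoms entering and the methoxy group leaving, still produces no difference that can be told from repeat measurements. No measurement is available that could explain this result. As far as these compounds go, both groups in this step keep a six-membered aromatic ring on the five-membered ring, so it remains open what a group without such a ring, such as cyclohexyl or a short alkyl chain, would do here. From the compounds shown here alone, it also remains open whether 3,5-dichlorophenyl, with both chlorine atoms on a ring of carbon only, would give a number like these, which would separate the part played by the ring nitrogen from that of the chlorine atoms.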